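A few compounds are considered here, and "the series" means these few. Any claim that something is new, unique, unknown or untested is made for them only; others in the source may bear on it.

Compound 1 `C#CCN(CCCOc1ccc2ccc(=O)oc2c1)Cc1ccc(C)cc1` is one of two compounds tested in an assay on isolated protein for inhibition of Amine oxidase [flavin-containing] B (Homo sapiens), read by fluorescence and Amplex Red, with stated times of 15 min and 20 min; a lower number here means a stronger inhibitor, a higher number a weaker inhibitor: compound 1 gives 7380 nM, the higher of the two numbers. Compound 2 `C#CCN(CCCCOc1ccc2ccc(=O)oc2c1)Cc1ccccc1` differs from it in two places at once, and in this assay compound 2 gives 978 nM. Compound 3 `C#CCN(CCCOc1ccc2ccc(=O)oc2c1)Cc1ccc(F)c(F)c1` carries 3,4-difluorophenyl in place of 4-methylphenyl on a saturated chain carbon bound to an amine nitrogen. Going by the values given here, no single-change step between measured compounds is known, so the expectation rests on this change alone: a modest step toward a lower number is expected, of size a 2.1-fold lower number from compound 1 to compound 3 (0.32 log units; beyond the scatter), possibly not beyond the usual scatter. Compound 3 is therefore estimated at 3500 nM, with a range from 1000 nM to 12000 nM.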

Compound 3, half-maximal inhibitory concentration: 4860 nM
Compound 3: the middle estimate sits 1.4-fold (0.14 log units) below what was measured, and the stated range covers the measured number.
By their numbers in this assay, from the lowest: compound 2; then compounds 3 and 1 (each within the scatter of the next).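

In this assay, going by these compounds alone, the first single-place comparison at this position gives a 1.5-fold lower number from compound 1 to compound 3 (0.18 log units; within the scatter) when 3,4-difluorophenyl replaces 4-methylphenyl on a saturated chain carbon bound to an amine nitrogen. This step lies within the usual scatter, so this exchange does not separate the two compounds in this assay. No supporting measurement bears on this result. Still open, as far as these compounds go, is whether a different group here, such as a pyridine ring or a methoxy-bearing phenyl ring, would give a step beyond the scatter. From the compounds shown here alone, the effect of a longer chain alone also remains open.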